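Unmeasured Quinazoline Thioether Against a Shared Detection Limit

The source may report more compounds than this note shows. Statements on the series, on what has been measured and on what is new or still open speak of the compounds shown alone.

The measured compounds:
compound 1, `CC(C)c1nc(SCc2ccc(-c3ccccc3C#N)cc2)c2ccccc2n1`, > 100000 nM
compound 2, `N#Cc1ccccc1-c1ccc(CSc2nc(SCc3ccc(F)cc3)nc3ccccc23)cc1`, > 100000 nM
compound 3, `COC(=O)c1ccccc1-c1ccc(CSc2nc(C(C)C)nc3ccccc23)cc1`, > 100000 nM

Compound 1 is the starting point. In an assay on isolated protein for inhibition of phosphodiesterase 7 (Homo sapiens), read by scintillation proximity assay and cAMP accumulation, with a stated time of 1 h (on this read-out higher numbers stand for weaker inhibition and lower numbers for stronger inhibition), compound 1 gives > 100000 nM, and this is a limit of the assay, not a number. For compound 2 the value > 100000 nM is likewise a limit. For compound 3 the value > 100000 nM is also a limit. So compound 1 stands at the limit, together with every other value shown; all three sit at the limit of > 100000 nM in this assay, at which 3 of the 3 values shown sit.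

Compound 4 is `CC(C)c1nc(SCc2ccc(-c3ccc(C(=O)O)cc3)cc2)c2ccccc2n1`. Its change from compound 1 is 4-carboxyphenyl in place of 2-cyanophenyl on an aromatic carbon.

Two measured steps start from compound 1. The step that the two limits leave unreadable from compound 1 to compound 2 cannot be read, and the step that the two limits leave unreadable from compound 1 to compound 3 cannot be read either, because both ends are limits. Nothing measured therefore tells how the change to compound 4 acts on this assay. The nearest comparison is compound 3, where one group on the same phenyl ring was exchanged and the value stayed a limit. The expectation for compound 4 is therefore a step that the limit leaves unreadable from compound 1 to compound 4, most probably again only a limit. Compound 4 is estimated at 150000 nM, with a range from 30000 nM to 1000000 nM.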

Compound 4, half-maximal inhibitory concentration: 930 nM
Beside the measured number, compound 4's estimate is 160-fold (2.21 log units) above it; the whole stated range lies above it.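

For the compounds shown here, compound 4 shows that the group on this phenyl ring can move a compound from the limit to a readable value in this assay, something the earlier compounds never showed. Putting 4-carboxyphenyl in place of 2-cyanophenyl gives an at least 100-fold lower number from compound 1 to compound 4 (2.03 log units; beyond the scatter), and putting it in place of 2-(methoxycarbonyl)phenyl gives an at least 100-fold lower number from compound 3 to compound 4 (2.03 log units; beyond the scatter). Both steps start from a limit, so their true size stays open, and the earlier steps cannot be read at all: the limit of > 100000 nM in this assay, at which 3 of the 4 values shown sit.

Each of these changes alters both the group and where it sits on the ring, so the compounds shown cannot tell which of the two matters. They also leave open how an amide or a tetrazole would read at this place on the same core.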